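The source may hold more compounds than are shown below. What is called first, only, known or untested is meant among the compounds shown, and "the series" means these compounds.

In a functional assay on ACHN cells (Homo sapiens) for antiproliferative activity, read by sulforhodamine B assay (on this read-out higher numbers stand for weaker inhibition of growth and lower numbers for stronger inhibition of growth), compound 2 `CC(C)C1CC(=O)c2s/c(=N/C3CCCCC3)oc2C1` gives 6700 nM, the second highest of the three numbers; compound 1 `CC(C)C1CC(=O)c2s/c(=N/c3ccccc3)oc2C1` gives 3080 nM and compound 3 `CC1CC(=O)c2s/c(=N/c3ccc(Cl)cc3)oc2C1` gives 12400 nM. Compound 4 `CC(C)C1CC(=O)c2s/c(=N/c3ccc(F)cc3)oc2C1` differs from compound 2 by 4-fluorophenyl in place of cyclohexyl on a double-bonded nitrogen. Within the data shown here, the only measured step that bears on this is the opposite exchange, a 2.2-fold higher number from compound 1 to compound 2 (0.34 log units; beyond the scatter), which lies beyond the scatter. Compound 3 differs from compound 4 in more than one place, so its number alone does not isolate the ring change. Because of a 2.2-fold higher number from compound 1 to compound 2 (0.34 log units; beyond the scatter) compound 4 is expected to show a step of a 2.0-fold lower number from compound 2 to compound 4 (0.31 log units; beyond the scatter), toward a lower number. The estimate for compound 4 in this assay is 3300 nM, with a range from 1400 nM to 8000 nM.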

Compound 4, concentration for 50% growth inhibition: 3670 nM
Compound 4: middle estimate off by 1.1-fold (0.05 log units), on the low side, within the range that was stated.
By their numbers in this assay, from the lowest: compounds 1, 4, 2 and 3 (each within the scatter of the next, the first and the last beyond it).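

In this assay the exchange on the double-bonded nitrogen gives a 1.8-fold lower number from compound 2 to compound 4 (0.26 log units; within the scatter) and so does not separate 4-fluorophenyl from cyclohexyl, although phenyl and cyclohexyl did separate. Fluoro in place of hydrogen on an aromatic carbon gives a 1.2-fold higher number from compound 1 to compound 4 (0.08 log units; within the scatter) and so leaves the number within the scatter of the unsubstituted phenyl compound. No measurement shown offers an explanation for either step. Open, from the compounds shown here alone, is whether a methoxy or amino group in place of the fluoro, or a straight alkyl chain in place of the ring on the double-bonded nitrogen, would move the number beyond the scatter.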